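This account rests on a few compounds, and the source may have more. Where it says the series, first, only, none or still open, it means among the compounds named here.

Compound 1 `Fc1cc2nc(-c3cncnc3)n(C3CC3)c2cc1F`: 2270 nM
Compound 2 `Fc1cc2nc(-c3cncnc3C3CC3)n(C3CC3)c2cc1F`: > 10000 nM
Compound 3 `CNc1ncncc1-c1nc2cc(F)c(F)cc2n1C1CC1`: 390 nM

All three share one core and differ on a single aromatic carbon. In an ADME assay on cells for inhibition of cytochrome P450 11B1, mitochondrial (Homo sapiens), read by HPLC, with a stated time of 60 min (a higher number here means a weaker inhibitor, a lower number a stronger inhibitor), compound 1 gives 2270 nM. Compound 2 reaches only a limit of the assay, > 10000 nM, which is the limit of > 10000 nM in this assay, at which 1 of the 3 values shown sits. Compound 3 gives 390 nM, the lowest number shown. Adding cyclopropyl gave an at least 4.4-fold higher number from compound 1 to compound 2 (0.64 log units; beyond the scatter), adding methylamino gave a 5.8-fold lower number from compound 1 to compound 3 (0.76 log units; beyond the scatter), and between those two groups there was an at least 25-fold lower number from compound 2 to compound 3 (1.40 log units; beyond the scatter). Compound 4 `Fc1cc2nc(-c3cncnc3NCCC(F)(F)F)n(C3CC3)c2cc1F` is not yet measured; it carries 2,2,2-trifluoroethyl in place of hydrogen on a saturated chain carbon bound to a nitrogen on an aromatic ring. Among the measured compounds shown here, since the only favourable step was a 5.8-fold lower number from compound 1 to compound 3 (0.76 log units; beyond the scatter) with a small group, and the bulkier cyclopropyl gave an at least 4.4-fold higher number from compound 1 to compound 2 (0.64 log units; beyond the scatter), a modest weakening is expected: a 2.3-fold higher number from compound 3 to compound 4 (0.36 log units; beyond the scatter). Compound 4 is thus estimated at 900 nM, between 200 nM and 4500 nM.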

Compound 4, half-maximal inhibitory concentration: 378 nM
For compound 4 the middle estimate is 2.4-fold (0.38 log units) above the measured one; low and high end bracket the measured number.
By their numbers in this assay, from the lowest: compounds 4 and 3 (each within the scatter of the next); then compound 1. At a limit, above all of these: compound 2.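

Placed on a saturated chain carbon bound to a nitrogen on an aromatic ring, 2,2,2-trifluoroethyl makes no difference that this assay can separate: a 1.0-fold lower number from compound 3 to compound 4 (0.01 log units; within the scatter). The (3,3,3-trifluoropropyl)amino group thus keeps the gain seen with methylamino, with a 6.0-fold lower number from compound 1 to compound 4 (0.78 log units; beyond the scatter), and it also stands far from cyclopropyl, with an at least 26-fold lower number from compound 2 to compound 4 (1.42 log units; beyond the scatter). Compound 2 gives no true number here, only a limit: the limit of > 10000 nM in this assay, at which 1 of the 4 values shown sits.

Still open, on these data alone, is how a plain amino group would read in this assay. So is a chain ending in a hydroxyl or a carboxylic acid on the same nitrogen.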